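Replacing the 4-sulfamoylphenyl group of compound 2

A few compounds are considered here, and "the series" means these few. Any claim that something is new, unique, unknown or untested is made for them only; others in the source may bear on it.

In a functional assay on MDA-MB-231 cells (Homo sapiens) for inhibition, read by MTT assay, with a stated time of 48 h (on this read-out higher numbers stand for weaker inhibition of growth and lower numbers for stronger inhibition of growth), compound 2 (`NS(=O)(=O)c1ccc(NC(=S)Nc2ccc3ncnc(Nc4cccc(Br)c4)c3c2)cc1`) has only a limit, > 30000 nM and no number. Compound 3 (`O=S(=O)(Nc1nccs1)c1ccc(NC(=S)Nc2ccc3ncnc(Nc4cccc(Br)c4)c3c2)cc1`) likewise has only a limit, > 30000 nM and no number. Together these two make up the limit of > 30000 nM in this assay, at which 2 of the 3 values shown sit, and nothing finer is known of them. Compound 1 (`Oc1ccc(Nc2ncnc3ccc(NC(=S)NCc4ccccc4)cc23)cc1`) alone gives a number in this assay with 27000 nM as its value.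

Compound 4 (`FC(F)(F)c1cccc(NC(=S)Nc2ccc3ncnc(Nc4cccc(Br)c4)c3c2)c1`) departs from compound 2 in one place: 3-(trifluoromethyl)phenyl in place of 4-sulfamoylphenyl on an amide-type nitrogen and the rest of the structure stays the same. In words, 3-(trifluoromethyl)phenyl stands in place of 4-sulfamoylphenyl on an amide-type nitrogen. Among the measured compounds shown here, the one measured step, a step that the two limits leave unreadable from compound 2 to compound 3 gives no size to carry over. For the measured compounds named here, only a modest gain is expected, because compound 1 gives 27000 nM as the sole measured number. The expected change is an at least 1.5-fold lower number from compound 2 to compound 4 (0.17 log units; that floor lies within the scatter) towards stronger inhibition of growth, and it is loosely estimated. Compound 4 is estimated at 20000 nM with an expected range from 6000 nM to 45000 nM in this reading.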

Compound 4, concentration for 50% growth inhibition: 1400 nM
Beside the measured number, compound 4's estimate is 14-fold (1.15 log units) above it; measured number outside the range, below it.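

At the amide-type nitrogen, this assay now gives a readable step, an at least 21-fold lower number from compound 2 to compound 4 (1.33 log units; beyond the scatter), with 3-(trifluoromethyl)phenyl in place of 4-sulfamoylphenyl. The true size of this step is not known and it has only a lower bound, because compound 2 stands at a limit and not at a number: the limit of > 30000 nM in this assay, at which 2 of the 4 values shown sit. Where the step from compound 2 to compound 3 could not be read, compound 4 shows that the group on this nitrogen can bring the read-out to a measured number while the rest of the structure stays the same.

On these data alone, whether this gain belongs to the trifluoromethyl group or to the loss of the sulfamoyl group stays open. As far as these compounds go, how a plain phenyl group, or a phenyl group carrying a nitrile or a methoxy group, would read on this nitrogen is also open.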